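The compounds below may be only part of what the source reports. "The series", "measured", "known", "first", "only" and "open" are said of these compounds alone.

Working notes on the series. Two compounds with the same core and different saturated chains have been measured. In a functional assay on B16-F1 cells (Mus musculus) for antiproliferative activity, read by sulforhodamine B assay, with a stated time of 48 h (a lower number here means a stronger inhibitor, a higher number a weaker inhibitor), compound 1 `CCCCCCCCCCCCNC(=O)c1c[nH]c(-c2ccccc2)n1` gives 30000 nM and compound 2 `CCCCCCCCCCCCCCCCNC(=O)c1c[nH]c(-c2ccccc2)n1` gives 39700 nM. These two values lie within the scatter of each other, so compound 2 stands level with compound 1 and neither can be ranked ahead.

Compound 3 `CCCCCCCCCCCCCCCCCCNC(=O)c1c[nH]c(-c2ccccc2)n1` differs from compound 2 by one change: ethyl in place of hydrogen on a saturated chain carbon, ten or more bonds along the chain from an amide-type nitrogen. In words, this is ethyl in place of hydrogen on a saturated chain carbon, ten or more bonds along the chain from an amide-type nitrogen. Within the data shown here, only one measured step bears on it, the exchange of butyl for hydrogen at the same kind of place, a 1.3-fold higher number from compound 1 to compound 2 (0.12 log units; within the scatter), and that step stayed within the scatter. A single step cannot establish a trend, and the data do not show whether the flat response continues.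

No shift beyond the scatter is therefore expected in this assay, and no direction is favoured. The expected step is a 1.1-fold higher number from compound 2 to compound 3 (0.02 log units; within the scatter). For compound 3 the estimated value is 42000 nM, with an expected range of 20000 nM to 90000 nM.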

Compound 3, half-maximal inhibitory concentration: > 30000 nM
Compound 3: a limit, no number; the forecaster's own chance of this, stated with the estimate: 20%; the middle value is on the limit's open side.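

In this assay compound 3 gives > 30000 nM, which is a limit and not a number: the limit of > 30000 nM in this assay, at which 1 of the 3 values shown sits.

The step from compound 2 cannot be read, so the flat response seen so far is neither extended nor broken by this ethyl change. Among these compounds, the one step with a readable direction is a number no lower from compound 1 to compound 3 (the limit leaves the size open), so hexyl in place of hydrogen on this saturated chain carbon brings no stronger inhibition in this assay, although the size of the change stays unknown.

The compounds shown leave open whether the number continues to stay flat or rises as the chain grows, since no value for the longest chain can be placed. They also leave open whether a shorter octyl chain, or a chain carrying an amine or a carboxylic acid, would give a lower number in this assay than these saturated chains do.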